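Ethyl to Benzyl on a Cytotoxicity Read-Out

The source may hold more compounds than are shown below. What is called first, only, known or untested is meant among the compounds shown, and "the series" means these compounds.

Measured compounds:
compound 1, `CC(C)(C)OC(=O)c1cccc(NC(=O)C2CCCN(C(=O)c3cc(C(F)(F)F)cc(C(F)(F)F)c3)C2)c1`, 0%
compound 2, `O=C(Nc1cccc(OCCc2ccccn2)c1)C1CCCN(C(=O)c2cc(C(F)(F)F)cc(C(F)(F)F)c2)C1`, 5%
compound 3, `CCc1cccc(NC(=O)C2CCCN(C(=O)c3cc(C(F)(F)F)cc(C(F)(F)F)c3)C2)c1`, 0%

All three were tested in an ADME assay on PC-3 cells (Homo sapiens) for cytotoxicity, read by WST assay, tested at 100 uM (on this read-out lower numbers stand for less inhibition and higher numbers for more inhibition at the one concentration tested (going by the name of the read-out)), and none of them registers beyond the scatter. Compound 3 stands level with compound 1 at the digits printed, the two together the lowest of the three numbers; its nearest neighbour is compound 1, with no change at the digits printed from compound 1 to compound 3 (within the scatter), and its furthest is compound 2, with a number 5 percentage points lower from compound 2 to compound 3 (within the scatter). The remaining pair, a number 5 percentage points higher from compound 1 to compound 2 (within the scatter), likewise stays within the scatter, so the three measured compounds form a single flat band on this read-out.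

Compound 4, `O=C(Nc1cccc(Cc2ccccc2)c1)C1CCCN(C(=O)c2cc(C(F)(F)F)cc(C(F)(F)F)c2)C1`, differs from compound 3 in one place: phenyl in place of methyl on a saturated chain carbon bound to an aromatic carbon. The same difference, cut one bond further out, reads ethyl to benzyl.

Going by the values given here, no measured step alters this saturated chain carbon, so there is no direct precedent. What the data offer is that every exchange of the substituent on the aromatic carbon, across compounds 1, 2 and 3, left this assay flat. Compound 4 is therefore expected to stay in the same band, with no step beyond the scatter. Compound 4 is estimated to give 3%, between 0% and 15%. The expected step is a number 3 percentage points higher from compound 3 to compound 4 (within the scatter).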

Compound 4, a percentage reported as inhibition, at one concentration (the size of the read-out at that concentration, not a potency): 0%
Estimate against measurement, compound 4: 3 percentage points above, and the stated range covers the measured number.
By their numbers in this assay, from the lowest: compounds 1, 3, 4 and 2 (each within the scatter of the next).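

Going by these compounds alone, at the saturated chain carbon bound to an aromatic carbon, phenyl in place of methyl brings in a six-membered aromatic ring of carbon only, and in this assay the change reads no change at the digits printed from compound 3 to compound 4 (within the scatter), the first measured exchange at this carbon and one that leaves the read-out flat. Benzyl on the aromatic carbon also sits with the two other substituents compared there, with a number 5 percentage points lower from compound 2 to compound 4 (within the scatter) and no change at the digits printed from compound 1 to compound 4 (within the scatter), so a ring of carbon only at this place joins the pyridine-bearing 2-(pyridin-2-yl)ethoxy, tert-butoxycarbonyl and ethyl in one band, with no step beyond the scatter. Nothing in the available data explains why this position stays flat on this read-out.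

Whether any group here can move the number beyond the scatter remains open, since an amine or a carboxylic acid on the phenyl ring of the benzyl group, or a longer chain in place of its saturated carbon, does not appear among these compounds. With all four compounds in one band, the series also leaves open whether changes elsewhere on the shared core would do so.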